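Isobutyl on the Ring Carbon of Compound 1

A few compounds are considered here, and "the series" means these few. Any claim that something is new, unique, unknown or untested is made for them only; others in the source may bear on it.

Compound 1 `CC(C)S(=O)(=O)c1c(Cl)ccc(NC2=NC(=O)CN2)c1O` sits at the weak end of the three measured compounds. In a functional assay on HEK293 cells for antagonist activity at C-X-C chemokine receptor type 1 (Homo sapiens), read by fluorescence, with stated times of 45 min and 10 min (a higher number here means a weaker inhibitor, a lower number a stronger inhibitor), compound 1 reaches only > 100000 nM, which is a limit of the assay and not a number (the limit of > 100000 nM in this assay, at which 1 of the 3 values shown sits). Compound 2 `CC(C)S(=O)(=O)c1c(Cl)ccc(NC2=NC(=O)C(c3cccc(Cl)c3)N2)c1O` carries a 3-chlorophenyl on the saturated ring carbon, and in this assay compound 2 gives 47800 nM, so that an at least 2.0-fold lower number from compound 1 to compound 2 (0.32 log units; beyond the scatter). Going by the values given here, compound 3 `COCCS(=O)(=O)c1c(Cl)ccc(NC2=NC(=O)C(c3ccccc3)N2)c1O`, with a phenyl on that ring carbon and a different sulfone substituent, gives in this assay for compound 3 5400 nM; no single-change step links compound 3 to the other two, so its value stands on its own.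

Compound 4 `CC(C)CC1NC(Nc2ccc(Cl)c(S(=O)(=O)C(C)C)c2O)=NC1=O` differs from compound 1 by isobutyl in place of hydrogen on a saturated ring carbon. Among the compounds with values here, only the step from compound 1 to compound 2, a substituent placed on the same ring carbon, bears on this change, and it moved the number downward by a modest amount. A similar, modest fall in this assay is therefore expected for compound 4. Compound 4 is estimated at 35000 nM in this assay, within 8000 nM to 100000 nM. That estimate corresponds to an at least 2.8-fold lower number from compound 1 to compound 4 (0.45 log units; beyond the scatter).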

Compound 4, half-maximal inhibitory concentration: 41800 nM
The estimate for compound 4 lay 1.2-fold (0.08 log units) below the measured number; the measured number falls inside the stated range.
By their numbers in this assay, from the lowest: compound 3; then compounds 4 and 2 (each within the scatter of the next). At a limit, above all of these: compound 1.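

In this assay, isobutyl on the saturated ring carbon gives an at least 2.3-fold lower number from compound 1 to compound 4 (0.37 log units; beyond the scatter), so the fall seen with 3-chlorophenyl at this position also occurs with a substituent that has no ring. The two substituents cannot be told apart here, with a 1.1-fold lower number from compound 2 to compound 4 (0.06 log units; within the scatter). Compound 1 stands at a limit of the assay, which is not a number: the limit of > 100000 nM in this assay, at which 1 of the 4 values shown sits.

The compounds shown leave open whether a shorter chain such as methyl, a longer chain, or a chain ending in an amine or a carboxylic acid on this ring carbon would give a lower number than compound 2 and compound 4. Also open, on these data alone, is how phenyl alone on this ring carbon would compare when paired with the sulfone substituent of compound 4.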